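This account rests on a few compounds, and the source may have more. Where it says the series, first, only, none or still open, it means among the compounds named here.

Measured so far: compound 1 `O=C(CCN1CCN(c2ccc(F)cc2)CC1)c1ccc(F)c(F)c1` gives 385000 nM in an ADME assay on Vero cells (Chlorocebus sabaeus) for cytotoxicity, read by resazurin assay, with a stated time of 72 h; on this read-out lower numbers stand for stronger inhibition and higher numbers for weaker inhibition; compound 2 `O=C(CCN1CCN(c2ccc(C(F)(F)F)cc2)CC1)c1ccc(F)c(F)c1` gives 14000 nM; compound 3 `O=C(CCN1CCN(c2ccc(F)cc2)CC1)c1ccc(C(F)(F)F)cc1` gives 28500 nM.

Compound 2 differs from compound 1 by trifluoromethyl in place of fluoro on an aromatic carbon, and this change gave a 28-fold lower number from compound 1 to compound 2 (1.44 log units; beyond the scatter). How the core of compound 3 differs from the core of compound 1 is not broken down here; their values alone show that compound 3 gives a lower number than compound 1, and a higher number than compound 2.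

Compound 4 `O=C(CCN1CCN(c2ccc(C(F)(F)F)cc2)CC1)c1ccc(C(F)(F)F)cc1` is not yet measured in this assay. It differs from compound 3 by trifluoromethyl in place of fluoro on an aromatic carbon, the same change that was made from compound 1 to compound 2. Because that earlier change gave a 28-fold lower number from compound 1 to compound 2 (1.44 log units; beyond the scatter), a lowering of the number is expected here too, though the earlier step was large and a somewhat smaller one is estimated: a 7.1-fold lower number from compound 3 to compound 4 (0.85 log units; beyond the scatter). For compound 4 the value in this assay is estimated at 4000 nM, expected to lie between 1000 nM and 15000 nM.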

Compound 4, half-maximal inhibitory concentration: 49200 nM
Estimate against measurement, compound 4: 12-fold (1.09 log units) below; the whole stated range lies below it.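

In this assay, putting trifluoromethyl in place of fluoro gave a 1.7-fold higher number from compound 3 to compound 4 (0.24 log units; within the scatter), so the large lowering seen on the core of compound 1 did not carry over to the core of compound 3, and the two steps clearly differ: the same change on two cores in this assay, a 28-fold lower number (1.44 log units; beyond the scatter) from compound 1 to compound 2 and a 1.7-fold higher number (0.24 log units; within the scatter) from compound 3 to compound 4, 47-fold (1.68 log units) apart, beyond the scatter of two such steps

With trifluoromethyl on both sides, 4-(trifluoromethyl)phenyl in place of 3,4-difluorophenyl on the carbonyl carbon gave a 3.5-fold higher number from compound 2 to compound 4 (0.55 log units; beyond the scatter), so the group on that carbonyl carbon also shifts the number. The size of this change therefore depends on the core in these two pairs, but two pairs do not show why, nor what it would do on a further core.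

As far as these compounds go, it remains open whether a chloro group or a nitrile would behave alike on both cores. From the compounds shown here alone, the effect of a longer chain to the carbonyl also remains open.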